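From 4-methylphenyl to 3-hydroxyphenyl: a small expected step

The source may report more compounds than this note shows. Statements on the series, on what has been measured and on what is new or still open speak of the compounds shown alone.

Values in an ADME assay on HEK293 cells (Homo sapiens) for cytotoxicity (a higher number here means a weaker inhibitor, a lower number a stronger inhibitor), so far
Compound 1 `CCCCCCCCCCCCCCNC(=O)[C@H](CO)/N=C/c1ccccc1OC` gives 79200 nM
Compound 2 `CCCCCCCCCCCCCCNC(=O)[C@H](CO)/N=C/c1ccc(O)cc1` gives 71700 nM
Compound 3 `CCCCCCCCCCCCCCNC(=O)[C@H](CO)/N=C/c1ccc(C)cc1` gives 47300 nM

In this assay compound 3 stands at 47300 nM and cannot be separated from the other two (a 1.7-fold lower number from compound 1 to compound 3 (0.22 log units; within the scatter) and a 1.5-fold lower number from compound 2 to compound 3 (0.18 log units; within the scatter)). Compound 4 `CCCCCCCCCCCCCCNC(=O)[C@H](CO)/N=C/c1cccc(O)c1` has not yet been measured. It carries 3-hydroxyphenyl in place of 4-methylphenyl on a carbon with a double bond to nitrogen. The nearest evidence is methyl in place of hydroxy on an aromatic carbon (a 1.5-fold lower number from compound 2 to compound 3 (0.18 log units; within the scatter)). The swap of 2-methoxyphenyl for 4-hydroxyphenyl also stayed small (a 1.1-fold lower number from compound 1 to compound 2 (0.04 log units; within the scatter)). Neither step leaves the scatter, so no step beyond the scatter is expected here. The expected result is a 1.3-fold higher number from compound 3 to compound 4 (0.12 log units; within the scatter) and remains an estimate. Compound 4 is expected at 62000 nM (estimated range 35000 nM to 105000 nM).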

Compound 4, half-maximal inhibitory concentration: 77500 nM
Compound 4: middle estimate off by 1.3-fold (0.10 log units), on the low side, and the stated range covers the measured number.
By their numbers in this assay, from the lowest: compounds 3, 2, 4 and 1 (each within the scatter of the next).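

In this assay, 3-hydroxyphenyl on this carbon cannot be separated from 4-hydroxyphenyl (a 1.1-fold higher number from compound 2 to compound 4 (0.03 log units; within the scatter)), so these two hydroxy placements on the phenyl ring give no readable difference. It also cannot be separated from 4-methylphenyl (a 1.6-fold higher number from compound 3 to compound 4 (0.21 log units; within the scatter)) or 2-methoxyphenyl (a 1.0-fold lower number from compound 1 to compound 4 (0.01 log units; within the scatter)), leaving all four aryl groups within the scatter of one another. Nothing available accounts for this flat result. From the compounds shown here alone, whether an amine or a carboxylic acid on the phenyl ring would produce a step beyond the scatter remains open, as does the effect of a shorter chain on the amide nitrogen.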